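The source may report more compounds than this note shows. Statements on the series, on what has been measured and on what is new or still open speak of the compounds shown alone.

Compound 3 `CS(=O)(=O)Nc1cccc(-c2nc(C(c3ccc(F)cc3)c3ccc(F)cc3)sc2CC(=O)O)c1` stands highest of the two numbers measured in an in vitro functional assay on HEK285-7 cells for antagonist activity at prostaglandin D2 receptor 2 (Homo sapiens), read by BRET and beta-arrestin recruitment (on this read-out higher numbers stand for weaker inhibition and lower numbers for stronger inhibition), where compound 3 gives 370 nM. Compound 2 `O=C(O)Cc1sc(C(c2ccc(F)cc2)c2ccc(F)cc2)nc1-c1ccc(Cl)cc1` gives 180 nM in this assay. Compound 1 `Nc1nc(-c2ccc(Cl)cc2)c(CC(=O)O)s1` returns only a limit in this assay, > 100000 nM. Among the measured compounds shown here, the single measured step that bears on the next change is a 2.1-fold higher number from compound 2 to compound 3 (0.31 log units; beyond the scatter), a swap of the group on an aromatic carbon of the shared core. Compound 4 `O=C(O)Cc1sc(C(c2ccc(F)cc2)c2ccc(F)cc2)nc1-c1cc(F)nc(F)c1` differs from compound 3 by 2,6-difluoropyridin-4-yl in place of 3-(methanesulfonamido)phenyl on an aromatic carbon. Because that earlier swap gave a 2.1-fold higher number from compound 2 to compound 3 (0.31 log units; beyond the scatter), a step of similar modest size, in either direction, is expected here. Compound 4 is therefore estimated at 350 nM, with a range from 120 nM to 1000 nM. The expected step is a 1.1-fold lower number from compound 3 to compound 4 (0.02 log units; within the scatter).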

Compound 4, half-maximal inhibitory concentration: 110 nM
Beside the measured number, compound 4's estimate is 3.2-fold (0.50 log units) above it; measured number below the stated range.
By their numbers in this assay, from the lowest: compounds 4 and 2 (each within the scatter of the next); then compound 3. At a limit, above all of these: compound 1.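

In this assay, among the compounds shown here, the 2,6-difluoropyridin-4-yl group brings a 3.4-fold lower number from compound 3 to compound 4 (0.53 log units; beyond the scatter) and so shows that this position, next to the ring nitrogen, can also give a lower number beyond the scatter, which the one earlier step did not. Set against the 4-chlorophenyl group, the same entering group gives a 1.6-fold lower number from compound 2 to compound 4 (0.21 log units; within the scatter) and so these two groups cannot be told apart, while the 3-(methanesulfonamido)phenyl group stays higher than both. No measurement given here bears on the cause of these steps.

The compounds shown do not separate the nitrogen of the entering ring from its two fluorines. On these data alone, a pyridin-4-yl group without fluorine and a 3,5-difluorophenyl group at this position remain open.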